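This account rests on a few compounds, and the source may have more. Where it says the series, first, only, none or still open, it means among the compounds named here.

Compound 1 `COc1cc(/C=C/C(=O)/C=C/c2cccc3ccccc23)ccc1OCc1cn(CCOc2cc(=O)oc3ccccc23)nn1`: 89%
Compound 2 `COc1ccc(/C=C/C(=O)/C=C/c2ccc(OCc3cn(CCCCOc4cc(=O)oc5ccccc45)nn3)c(OC)c2)cc1OC`: 59%
Compound 3 `COc1cc(/C=C/C(=O)/C=C/c2cccs2)ccc1OCc1cn(CCOc2cc(=O)oc3ccccc23)nn1`: 76%

In a functional assay on THP-1 cells (Homo sapiens) for inhibition, read by sulforhodamine B assay, with a stated time of 48 h, tested at 50 uM (a higher number here means more inhibition of growth at the concentration tested, a lower number less inhibition of growth), compound 3 gives 76%, the second highest of the three numbers. It stands below compound 1 and above compound 2, and both gaps lie beyond the usual scatter.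

Compound 4 `COc1cccc(/C=C/C(=O)/C=C/c2ccc(OCc3cn(CCOc4cc(=O)oc5ccccc45)nn3)c(OC)c2)c1` has not been measured. It carries 3-methoxyphenyl in place of thiophen-2-yl on a double-bonded chain carbon bound to a double-bonded chain carbon.

Going by the values given here, one measured step touches this same place: a number 13 percentage points lower from compound 1 to compound 3 (beyond the scatter), a modest change that came with thiophen-2-yl replacing naphthalen-1-yl. Among the compounds with values here, compound 2 differs from the others in more than one place, so it offers no clean step, though its lower value is a caution. With a single step as a guide, only a small rise is expected, within the scatter. The expected change is a number 2 percentage points higher from compound 3 to compound 4 (within the scatter). The estimated value for compound 4 is 78%, with an expected range from 62% to 91%.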

Compound 4, percent growth inhibition at one concentration: 77%
The estimate for compound 4 lay 1 percentage points above the measured number, and the stated range covers the measured number.
By their numbers in this assay, from the lowest: compound 2; then compounds 3 and 4 (each within the scatter of the next); then compound 1.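

In this assay, the step from thiophen-2-yl to 3-methoxyphenyl is a number 1 percentage points higher from compound 3 to compound 4 (within the scatter), so at this position a five-membered aromatic ring with a sulfur atom and a larger six-membered carbon ring bearing a methoxy group cannot be told apart. Naphthalen-1-yl remains distinct, with a number 12 percentage points lower from compound 1 to compound 4 (beyond the scatter), so both smaller groups now sit beyond the scatter from it, and no compound that differs only here goes against this. Nothing measured here explains why naphthalen-1-yl stands apart.

From the compounds shown here alone, whether an amine or a carboxylic acid at this place would keep the number near that of compound 3 and compound 4 remains open. So does whether naphthalen-2-yl would match naphthalen-1-yl.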